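The source may hold more compounds than are shown below. What is called first, only, known or untested is meant among the compounds shown, and "the series" means these compounds.

Series notes. Compound 1 `NC(=O)c1cc(Cl)ccc1NC(=O)/C=C/c1ccccc1Br` is the reference point. Within the data shown here, in a functional assay on K562 cells (Homo sapiens) for antiproliferative activity, read by trypan blue exclusion, with a stated time of 48 h, tested at 10 uM (on this read-out lower numbers stand for less inhibition of growth and higher numbers for more inhibition of growth at the one concentration tested), compound 1 gives 49%, the lowest of the three numbers measured so far. Compound 2 `Cc1ccccc1/C=C/C(=O)Nc1ccc(Cl)cc1C(N)=O` gives 52.2%, a step of a number 3.2 percentage points higher from compound 1 to compound 2 (within the scatter); compound 3 `Cc1ccc(/C=C/C(=O)Nc2ccc(Cl)cc2C(N)=O)cc1` gives 64%, steps of a number 15 percentage points higher from compound 1 to compound 3 (beyond the scatter) and a number 11.8 percentage points higher from compound 2 to compound 3 (beyond the scatter).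

Compound 4 `NC(=O)c1cc(Br)ccc1NC(=O)/C=C/c1ccccc1Br` differs from compound 1 by bromo in place of chloro on an aromatic carbon, on the six-membered aromatic ring of carbon only bearing the carbamoyl group. Among the measured compounds shown here, no measured step touches this ring; the only halogen exchange in the set is that from compound 1 to compound 2, on the other ring, and it stayed within the scatter. A step beyond the scatter in this assay is therefore not expected.

For compound 4 the expected value in this assay is 50%, range 38% to 62%, an expected step of a number 1 percentage points higher from compound 1 to compound 4 (within the scatter).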

Compound 4, percent growth inhibition at one concentration: 46.2%
Compound 4: middle estimate off by 3.8 percentage points, on the high side, and the stated range covers the measured number.
By their numbers in this assay, from the lowest: compounds 4, 1 and 2 (each within the scatter of the next); then compound 3.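

In this assay bromo in place of chloro, meta to the carbamoyl group and para to a large group, gives a number 2.8 percentage points lower from compound 1 to compound 4 (within the scatter) and shows that this position takes either halogen without a step beyond the scatter at the one concentration tested. Among these compounds, this is the first step on this ring, as the earlier steps all lay on the other ring. Nothing available offers an explanation for this result.

Going by these compounds, whether an amine, a carboxylic acid or a methyl group at this position would give a step beyond the scatter remains open. On these data alone, whether compound 1 and compound 4 would stay this close at other concentrations also remains open.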